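The source may report more compounds than this note shows. Statements on the series, on what has been measured and on what is new or still open speak of the compounds shown alone.

Measured in a functional assay on HCT-116 cells (Homo sapiens) for inhibition, read by MTT assay, with a stated time of 72 h; a higher number here means a weaker inhibitor, a lower number a stronger inhibitor:

- compound 1 `COc1cc2c(Oc3ccc(NC(=O)c4nn(-c5ccccc5C)cc(C)c4=O)cc3F)ccnc2cc1OCCCC(=O)NO`: 2040 nM
- compound 2 `COc1cc2c(Oc3ccc(NC(=O)c4nn(-c5ccccc5)cc(C)c4=O)cc3F)ccnc2cc1OCCCC(=O)NO`: 660 nM
- compound 3 `COc1cc2c(Oc3ccc(NC(=O)c4nn(-c5ccccc5F)cc(C)c4=O)cc3F)ccnc2cc1OCCCC(=O)NO`: 1120 nM

Compound 3 cannot be ranked against the other two: the data show a 1.8-fold lower number from compound 1 to compound 3 (0.26 log units; within the scatter) and a 1.7-fold higher number from compound 2 to compound 3 (0.23 log units; within the scatter). Only a 3.1-fold lower number from compound 1 to compound 2 (0.49 log units; beyond the scatter) clears the scatter.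

Compound 4 `COc1cc2c(Oc3ccc(NC(=O)c4nn(-c5ccccc5F)cc(C)c4=O)cc3)ccnc2cc1OCCCC(=O)NO` differs from compound 3 by one swap, (hydrogen in place of fluoro on an aromatic carbon), which puts hydrogen in place of fluoro on an aromatic carbon. Going by the values given here, no measured step touches that carbon. The closest guide is the same pair of atoms exchanged elsewhere in the molecule, a 1.7-fold higher number from compound 2 to compound 3 (0.23 log units; within the scatter). With only that to go on, no step beyond the scatter is expected in this assay. The estimated change is a 1.1-fold lower number from compound 3 to compound 4 (0.05 log units; within the scatter). For compound 4 the estimated value is 1000 nM, with an expected range of 400 nM to 2500 nM.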

Compound 4, half-maximal inhibitory concentration: 950 nM
The estimate for compound 4 lay 1.1-fold (0.02 log units) above the measured number; low and high end bracket the measured number.
By their numbers in this assay, from the lowest: compounds 2, 4, 3 and 1 (each within the scatter of the next, the first and the last beyond it).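

In this assay, going by these compounds alone, hydrogen in place of fluoro on this aromatic carbon, ortho to a large group and meta to a large group, gives a 1.2-fold lower number from compound 3 to compound 4 (0.07 log units; within the scatter) and is the first measured step at this carbon. With the rest of compound 3 unchanged, the fluoro here can therefore give way to hydrogen without a step beyond the scatter. No measurement shown explains this result.

Going by these compounds, whether a chloro, a methoxy or an amine on this carbon would also stay within the scatter remains open. So does whether the same swap behaves alike with the methyl-bearing ring of compound 1.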